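The source may report more compounds than this note shows. Statements on the series, on what has been measured and on what is new or still open speak of the compounds shown alone.

Working notes on the series. Compound 1 `Cc1ccc(-c2nc(CNc3ccc(C(=O)NO)cc3)n(-c3ccccc3)n2)o1` gives 60.7% in an assay on Sf9 cells for inhibition of protein deacetylase HDAC6 (Homo sapiens), read by fluorescence, with a stated time of 40 min, tested at 100 nM; a higher number here means more inhibition at the concentration tested (going by the name of the read-out), a lower number less inhibition. Compound 2 `O=C(NO)c1ccc(NCc2nc(-c3ccncc3)nn2-c2ccccc2)cc1` gives 30.8% in this assay, and compound 3 `O=C(NO)c1ccc(NCc2nc(-c3ccc(Cl)cc3)nn2-c2ccccc2)cc1` gives 67.2%. Compound 3 holds the highest of the three numbers: its nearest neighbour is compound 1, with a number 6.5 percentage points higher from compound 1 to compound 3 (within the scatter), within the scatter, and the furthest is compound 2, with a number 36.4 percentage points higher from compound 2 to compound 3 (beyond the scatter), beyond the scatter.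

Compound 4 `O=C(NO)c1ccc(NCc2nc(-c3cccc4cnccc34)nn2-c2ccccc2)cc1` is not yet measured. The change is isoquinolin-5-yl in place of 4-chlorophenyl on an aromatic carbon. The entering group is counted with one hydrogen-bond acceptor, a ring nitrogen, and the measured steps that bear on a ring nitrogen at this position are a number 36.4 percentage points higher from compound 2 to compound 3 (beyond the scatter) and a number 29.9 percentage points lower from compound 1 to compound 2 (beyond the scatter), both beyond the scatter and both pointing the same way. Isoquinolin-5-yl is not pyridin-4-yl, so a smaller move than those steps is expected in this assay, downward, but still beyond the scatter. Compound 4 is therefore expected to give 48% in this assay. For compound 4 the expected range runs from 25% to 70%. The expected step is a number 19.2 percentage points lower from compound 3 to compound 4 (beyond the scatter).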

Compound 4, a percentage reported as inhibition, at one concentration (the size of the read-out at that concentration, not a potency): 40.2%
Beside the measured number, compound 4's estimate is 7.8 percentage points above it, and the stated range covers the measured number.
By their numbers in this assay, from the lowest: compounds 2 and 4 (each within the scatter of the next); then compounds 1 and 3 (each within the scatter of the next).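

In this assay, the larger isoquinolin-5-yl group, with its ring nitrogen, does not hold the level of the two groups without one (a number 27 percentage points lower from compound 3 to compound 4 (beyond the scatter); a number 20.5 percentage points lower from compound 1 to compound 4 (beyond the scatter)). Against pyridin-4-yl the step is small (a number 9.4 percentage points higher from compound 2 to compound 4 (within the scatter)), so across these four compounds the two groups counted with a ring nitrogen read alike and sit under the two without one, with no compound going against this, and the added fused ring does not lift the number beyond the scatter. Nothing given here accounts for this difference.

On these data alone, it remains open whether the ring nitrogen or the size of the group sets the level, which naphthalen-1-yl, the all-carbon counterpart of isoquinolin-5-yl, would separate. Also open, as far as these compounds go, is how a phenyl ring bearing an amine or a carboxylic acid would read at this carbon.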